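Moving one hydroxy group on compound 3

The source may hold more compounds than are shown below. What is called first, only, known or untested is meant among the compounds shown, and "the series" means these compounds.

In a physicochemical assay for solubility, using the shake flask method, with a stated time of 12 h (a lower number here means a less soluble compound, a higher number a more soluble compound), compound 3 (`O=C(/C=C/c1ccc(O)c(O)c1)/C=C/c1ccccc1O`) gives 111000 nM and stands highest of the three measured compounds. Well under it lie compound 2 (`O=C(/C=C/c1ccccc1O)CC(=O)/C=C/c1cccc(O)c1O`) at 11000 nM and compound 1 (`O=C(/C=C/c1cccc(O)c1O)CC(=O)/C=C/c1cccc(O)c1O`) at 5300 nM. Both of these also differ from compound 3 in the core.

Compound 4 (`O=C(/C=C/c1cccc(O)c1)/C=C/c1ccc(O)c(O)c1`) has the same atoms as compound 3, joined differently (3-hydroxyphenyl in place of 2-hydroxyphenyl on a double-bonded chain carbon bound to a double-bonded chain carbon). Within the data shown here, the one measured single-place step (a 2.1-fold higher number from compound 1 to compound 2 (0.32 log units; beyond the scatter)) is modest and bears only loosely on this change, since it removes a hydroxy group rather than moving one. Among the measured compounds shown here, no measured pair shows 3-hydroxyphenyl in place of 2-hydroxyphenyl, so the series gives no basis for a firm direction. The expected step (a 1.2-fold lower number from compound 3 to compound 4 (0.09 log units; within the scatter)) is therefore estimated to stay within the scatter. For compound 4 the estimated value is 90000 nM, with an expected range from 30000 nM to 220000 nM (wide, given the thin evidence).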

Compound 4, solubility: 60000 nM
Compound 4: middle estimate off by 1.5-fold (0.18 log units), on the high side; measured number inside the range.
By their numbers in this assay, from the lowest: compound 1; then compound 2; then compounds 4 and 3 (each within the scatter of the next).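

In this assay, among these compounds, the new step (a 1.9-fold lower number from compound 3 to compound 4 (0.27 log units; within the scatter)) gives the first measured reading of 3-hydroxyphenyl in place of 2-hydroxyphenyl on a double-bonded chain carbon bound to a double-bonded chain carbon. With the atoms unchanged, moving the hydroxy group at this position gives a step within the scatter, whereas the earlier step (a 2.1-fold higher number from compound 1 to compound 2 (0.32 log units; beyond the scatter)), which removes a hydroxy group on the core of compound 1, lies beyond it. Nothing available explains this result.

Still open, from the compounds shown here alone, is whether the number at this position stays within the scatter with a group other than a moved hydroxy, such as methoxy, an amine or a carboxylic acid. Also open, going by these compounds, is whether the same hydroxy move gives a similar step on the core of compound 1.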